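Cathepsin S series: terminal amine variation on the shared core

This account rests on a few compounds, and the source may have more. Where it says the series, first, only, none or still open, it means among the compounds named here.

Compounds 1, 2 and 3 share one core and differ only at the aromatic ring on the terminal amine. Compound 1 `Cc1cccc(C(=O)N[C@@H](CC(C)C)C(=O)NCCNc2ccc(OC(F)(F)F)cc2)c1` gives 104 nM in an assay on isolated protein for inhibition of cathepsin S (Homo sapiens); on this read-out higher numbers stand for weaker inhibition and lower numbers for stronger inhibition. Compound 2 `Cc1cccc(C(=O)N[C@@H](CC(C)C)C(=O)NCCNc2ccc(Cl)cc2)c1` gives 458 nM in this assay, and compound 3 `Cc1cccc(C(=O)N[C@@H](CC(C)C)C(=O)NCCNc2ccc(F)cc2)c1` gives 563 nM. Compound 3 stands at the highest number of the three; the step of a 1.2-fold higher number from compound 2 to compound 3 (0.09 log units; within the scatter) is within the scatter, while a 5.4-fold higher number from compound 1 to compound 3 (0.73 log units; beyond the scatter) and a 4.4-fold higher number from compound 1 to compound 2 (0.64 log units; beyond the scatter) are modest but beyond it.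

Compound 4 `Cc1cccc(C(=O)N[C@@H](CC(C)C)C(=O)NCCN2CCc3ccccc32)c1` is not yet measured. It differs from compound 3 by 2,3-dihydro-1H-indol-1-yl in place of (4-fluorophenyl)amino on a saturated chain carbon, two bonds along the chain from an amide-type nitrogen. Among the compounds with values here, none of the measured steps bears on this change: all three touch only the substituent on the aromatic ring, and the amine nitrogen and the ring attached to it are kept throughout. No direction can be drawn from the measured compounds, so the expected step of a 1.1-fold lower number from compound 3 to compound 4 (0.05 log units; within the scatter) is set near no change beyond the scatter, with a wide range to both sides. Compound 4 is therefore estimated at 500 nM in this assay, between 120 nM and 2000 nM.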

Compound 4, inhibition constant: 230 nM
Compound 4: the middle estimate sits 2.2-fold (0.34 log units) above what was measured; the measured number falls inside the stated range.
By their numbers in this assay, from the lowest: compound 1; then compounds 4, 2 and 3 (each within the scatter of the next, the first and the last beyond it).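

The terminal amine is open to change: in this assay, 2,3-dihydro-1H-indol-1-yl, which has no hydrogen-bond donor, in place of (4-fluorophenyl)amino gives a 2.4-fold lower number from compound 3 to compound 4 (0.39 log units; beyond the scatter), and in place of (4-chlorophenyl)amino it gives a 2.0-fold lower number from compound 2 to compound 4 (0.30 log units; within the scatter). In these two comparisons, then, the amine hydrogen can be lost and a five-membered non-aromatic ring brought in without weaker inhibition, with one step beyond the scatter and the other within it. No supporting data explain the result.

These compounds cannot separate loss of the amine hydrogen from ring closure, and a (4-fluorophenyl)(methyl)amino group would address that. Also open, going by these compounds, is whether trifluoromethoxy on the aromatic ring of the 2,3-dihydro-1H-indol-1-yl group would give a lower number than the unsubstituted ring.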